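The source may hold more compounds than are shown below. What is called first, only, known or untested is meant among the compounds shown, and "the series" means these compounds.

Measured so far:
- compound 1, `c1ccc2c(c1)CN[C@@H](CN(CCCCNCc1ccncc1)[C@H]1CCCc3cccnc31)C2`: > 30000 nM
- compound 2, `c1ccc2c(c1)CN[C@@H](CN(CCCCNCC1CCCCC1)[C@H]1CCCc3cccnc31)C2`: > 30000 nM
- compound 3, `NCc1ccccc1CN(C[C@H]1Cc2ccccc2CN1)[C@H]1CCCc2cccnc21`: > 30000 nM

In a functional assay on cells for agonist activity at C-X-C chemokine receptor type 4 (Homo sapiens), read by fluorescence and calcium flux, with a stated time of 90 s (a higher number here means that more compound is needed for the effect, a lower number that less compound is needed), compound 1 gives > 30000 nM, which is a limit of the assay and not a number. Compound 2 likewise reaches only a limit, > 30000 nM. Compound 3 also stops at a limit, > 30000 nM. The measured steps among the three are therefore unreadable: a step that the two limits leave unreadable from compound 1 to compound 2, a step that the two limits leave unreadable from compound 1 to compound 3 and a step that the two limits leave unreadable from compound 2 to compound 3. The one common observation is the limit of > 30000 nM in this assay, at which 3 of the 3 values shown sit.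

Compound 4, `CC(C)(CN)CCN(C[C@H]1Cc2ccccc2CN1)[C@H]1CCCc2cccnc21`, is the next member to be run in this assay. Relative to compound 1 the change is 1-(aminomethyl)-1-methylethyl in place of 2-(((pyridin-4-yl)methyl)amino)ethyl on a saturated chain carbon, two bonds along the chain from an amine nitrogen. For the measured compounds named here, none of the measured steps gives a readable size, so no direction or magnitude can be drawn from them; the only guidance is that every recorded value sits at the same limit.

On that basis the step of a number no higher from compound 1 to compound 4 (the limit leaves the size open) is expected to be not readable, with compound 4 most likely stopping at the limit again. The estimate for compound 4 in this assay is 30000 nM, with a range from 10000 nM to 100000 nM, and a high chance that only a limit and no number is reported.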

Compound 4, half-maximal effective concentration: > 30000 nM
Compound 4 ended at the assay's limit (the forecaster's own chance of this, stated with the estimate: 75%); the middle value sits exactly at the limit.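

In this assay compound 4 gives > 30000 nM, a limit of the assay and not a number. The steps to compound 4 from compound 1, compound 2 and compound 3 cannot be read. The compounds shown leave open which structural change, if any, would yield a measurable value, with one common observation so far: the limit of > 30000 nM in this assay, at which 4 of the 4 values shown sit.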